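A few compounds are considered here, and "the series" means these few. Any claim that something is new, unique, unknown or untested is made for them only; others in the source may bear on it.

The series shares one core, seen in compound 1 `Cc1cc(NC(=O)Nc2ccc(C(C)(C)C)cc2)c2ccccc2n1`. In an ADME assay on HEK293 cells (Homo sapiens) for cytotoxicity, with a stated time of 72 h (a lower number here means that less compound is needed, a higher number that more compound is needed for the effect), compound 1 gives > 25000 nM, which is a limit of the assay rather than a number. Compound 2 `Cc1cc(NC(=O)Nc2ccc3[nH]cnc3c2)c2ccccc2n1` is measured at > 25000 nM, again only a limit. Compound 3 `COc1ccc(NC(=O)Nc2cc(C)nc3ccccc23)cc1F` likewise reaches only > 25000 nM, a limit. All three measured values therefore sit at the limit of > 25000 nM in this assay, at which 3 of the 3 values shown sit, so compound 1 stands level with the others and no ordering among them can be read. No pair of these compounds differs in one place only, and no measured step is available.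

Compound 4 `Cc1cc(NC(=O)Nc2ccc(SC(F)(F)F)cc2)c2ccccc2n1` is the next member to be measured. It differs from compound 1 by (trifluoromethyl)sulfanyl in place of tert-butyl on an aromatic carbon. Among the measured compounds shown here, with no step to lean on, the expectation for the step from compound 1 to compound 4 in this assay is a step that the limit leaves unreadable from compound 1 to compound 4, none beyond the scatter, with another limit the likeliest outcome. Compound 4 is accordingly estimated at 30000 nM, within a range from 12000 nM to 80000 nM.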

Compound 4, half-maximal effective concentration: 13000 nM
The estimate for compound 4 lay 2.3-fold (0.36 log units) above the measured number; the range from low to high includes it.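

In this assay, among the compounds shown here, compound 4 gives 13000 nM, the first actual number. The values of the other compounds shown remain limits: the limit of > 25000 nM in this assay, at which 3 of the 4 values shown sit. Placing (trifluoromethyl)sulfanyl instead of tert-butyl on this aromatic carbon gives an at least 1.9-fold lower number from compound 1 to compound 4 (0.28 log units; that floor lies within the scatter), so a change at this one place is enough to bring the read-out to a number, but the size of the step is known only as a floor, and that floor does not clear the scatter.

The compounds shown leave open how far apart compound 1 and compound 4 truly lie, since the value of compound 1 is only a limit. They also leave open what an amine or a carboxylic acid on this aromatic carbon would give in this assay, and whether any group here would give a step beyond the scatter.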